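This account rests on a few compounds, and the source may have more. Where it says the series, first, only, none or still open, it means among the compounds named here.

Working notes. In an assay on a protein complex for inhibition of CDK8/Cyclin C (Homo sapiens), with a stated time of 1 h (on this read-out higher numbers stand for weaker inhibition and lower numbers for stronger inhibition), compound 1 `CNC(=O)/C=C/c1ccncc1-c1ccc2ccccc2c1` gives 12.4 nM, the lowest of the two numbers recorded so far. Compound 2 `O=C(/C=C/c1ccncc1-c1ccc2ncccc2c1)N1CCOCC1` gives 1590 nM in this assay, a gap well beyond the scatter. Compound 3 `CNC(=O)CCc1ccncc1-c1ccc2ccccc2c1` has not yet been measured. It differs from compound 1 by 2-(methylcarbamoyl)ethyl in place of 2-(methylcarbamoyl)ethenyl on an aromatic carbon. Going by the values given here, no measured pair covers this change, so the expectation rests on compound 1 alone; a step toward weaker inhibition, beyond the scatter but moderate, is expected. For compound 3 the estimate in this assay is 60 nM, within a range of 15 nM to 250 nM. The estimated step is a 4.8-fold higher number from compound 1 to compound 3 (0.68 log units; beyond the scatter).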

Compound 3, half-maximal inhibitory concentration: 21.1 nM
Estimate against measurement, compound 3: 2.8-fold (0.45 log units) above; the range from low to high includes it.
By their numbers in this assay, from the lowest: compounds 1 and 3 (each within the scatter of the next); then compound 2.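

In this assay the exchange of 2-(methylcarbamoyl)ethenyl for 2-(methylcarbamoyl)ethyl on this aromatic carbon gives a 1.7-fold higher number from compound 1 to compound 3 (0.23 log units; within the scatter) and so does not separate the two side chains. Inhibition in this pair therefore does not depend on the double bond in the chain, a point the earlier compounds could not address, as they offered no single change at this position. Nothing on hand gives a reason for this result.

Still open, going by these compounds, is whether this position accepts a longer chain, or a carboxylic acid in place of the methylcarbamoyl end.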